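This account rests on a few compounds, and the source may have more. Where it says the series, first, only, none or still open, it means among the compounds named here.

Compound 1 `Cc1cccc(Cl)c1NC(=O)CN1CCN(c2nnc(Cc3ccncc3)c3ccccc23)CC1` gives 22600 nM in a functional assay on HT-29 cells (Homo sapiens) for cytotoxicity, read by MTT assay, with a stated time of 72 h; a lower number here means a stronger inhibitor, a higher number a weaker inhibitor. Compound 2 `O=C(CN1CCN(c2nnc(Cc3ccncc3)c3ccccc23)CC1)Nc1ccc(Br)cc1` gives 1990 nM in this assay. Compound 3 `COc1ccc(NC(=O)CN2CCN(c3nnc(Cc4ccccc4)c4ccccc34)CC2)cc1OC` gives 145000 nM in this assay.

Compound 3 stands highest of the three numbers, a weaker inhibitor than compound 1 and far weaker than compound 2. Compound 4 `O=C(CN1CCN(c2nnc(Cc3ccccc3)c3ccccc23)CC1)Nc1ccc(F)c(C(F)(F)F)c1` differs from compound 3 in one place: 4-fluoro-3-(trifluoromethyl)phenyl in place of 3,4-dimethoxyphenyl on an amide-type nitrogen. Among the measured compounds shown here, the only measured step, an 11-fold lower number from compound 1 to compound 2 (1.06 log units; beyond the scatter), also exchanged the aryl group on the amide-type nitrogen, and it was large. For the measured compounds named here, that step is the sole guide, though the pair of groups here is different and the shared core of compound 3 is not that of compounds 1 and 2. Compound 4 is therefore expected to give a lower number, a 5.8-fold lower number from compound 3 to compound 4 (0.76 log units; beyond the scatter), with wide uncertainty. The estimate for compound 4 is 25000 nM, within 5000 nM to 120000 nM.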

Compound 4, half-maximal inhibitory concentration: 4590 nM
The estimate for compound 4 lay 5.4-fold (0.74 log units) above the measured number, and the stated range ends above it.
By their numbers in this assay, from the lowest: compound 2; then compound 4; then compound 1; then compound 3.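

With the shared core held fixed, 4-fluoro-3-(trifluoromethyl)phenyl in place of 3,4-dimethoxyphenyl on the amide-type nitrogen gives a 32-fold lower number from compound 3 to compound 4 (1.50 log units; beyond the scatter) in this assay. Among the compounds shown here, the earlier exchange at this position was seen only on the core of compound 1, and this one shows that the position also responds on a second core. Nothing available here accounts for the change. The compounds shown leave open whether the fluorine, the trifluoromethyl or the loss of the methoxy groups carries the step. Also open, from the compounds shown here alone, is how an amine or a carboxylic acid on that phenyl ring would read.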